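Swapping the Aryl Sulfone Partner for Pyrimidin-5-yl

This account rests on a few compounds, and the source may have more. Where it says the series, first, only, none or still open, it means among the compounds named here.

Measured so far:
- compound 1, `COc1ccccc1S(=O)(=O)c1ccc(NC(=O)C(C)(O)C(F)(F)F)cc1`: 1600 nM
- compound 2, `CC(O)(C(=O)Nc1ccc(S(=O)(=O)c2ccncc2)c(O)c1)C(F)(F)F`: 1300 nM

Both compounds were tested in a functional assay (Cavia porcellus) with sulfonylurea receptors; K-ATP channels (Homo sapiens) as the target; a lower number here means a stronger inhibitor, a higher number a weaker inhibitor. Compound 1 has the highest of the two numbers, but compound 2 lies only 1300 nM away from it, a gap inside the usual scatter, so the two cannot be told apart. No change between measured compounds is available here.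

Compound 3, `CC(O)(C(=O)Nc1ccc(S(=O)(=O)c2cncnc2)cc1)C(F)(F)F`, is not yet measured. It differs from compound 1 in one place: pyrimidin-5-yl in place of 2-methoxyphenyl on a sulfonyl sulfur. In this assay no step beyond the scatter is expected in either direction, because compound 2 gives 1300 nM with a different ring on the same sulfonyl sulfur and still sits beside compound 1. The step from compound 1 is estimated at a 1.3-fold higher number from compound 1 to compound 3 (0.10 log units; within the scatter). Compound 3 is therefore expected to reach about 2000 nM, with a likely range from 700 nM to 6000 nM.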

Compound 3, half-maximal inhibitory concentration: > 30000 nM
Compound 3: no number, only a limit (the forecaster's own chance of this, stated with the estimate: 10%); at least 15-fold (1.17 log units) between middle value and limit.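

In this assay compound 3 gives > 30000 nM, which is a limit of the assay and not a number. Replacing 2-methoxyphenyl with pyrimidin-5-yl on a sulfonyl sulfur gives an at least 18-fold higher number from compound 1 to compound 3 (1.27 log units; beyond the scatter), so the group at this place can decide whether inhibition appears at all within the tested range, something compound 1 and compound 2 alone gave no sign of. The true size of the step stays unknown, as it rests on a limit: the limit of > 30000 nM in this assay, at which 1 of the 3 values shown sits.

This single swap removes the methoxy group and brings in two ring nitrogens at once, so the compounds shown cannot say which of these changes goes with the loss. On these data alone, a plain phenyl ring or a pyridin-3-yl ring on the same sulfonyl sulfur would help to separate the two, and how either would stand remains open.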